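The source may hold more compounds than are shown below. What is called first, only, known or untested is meant among the compounds shown, and "the series" means these compounds.

Measured so far in an in vitro ADME assay on microsomes from liver (Homo sapiens) for metabolic stability; on this read-out higher numbers stand for a longer-lived compound and lower numbers for a shorter-lived compound:
- compound 1 `O=c1[nH]c(C2=Cc3ccccc3OC2)nc2ccc(-c3cn[nH]c3)cc12`: 7.3 h
- compound 2 `Cc1ccc2c(c1)CC(c1nc3ccc(-c4cn[nH]c4)cc3c(=O)[nH]1)CO2`: 0.517 h

Compound 2 holds the lower of the two numbers in this assay; compound 1, the analogue without the methyl, sits above it, and the gap between compound 2 and compound 1 lies beyond the usual scatter. The pair is the only one at hand, so nothing beyond these two values is known about the series.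

Compound 3 `COCCNC(=O)c1ccc2c(c1)CC(c1nc3ccc(-c4cn[nH]c4)cc3c(=O)[nH]1)CO2` is the next member and has not yet been measured in this assay. It differs from compound 2 in one place: (2-methoxyethyl)carbamoyl in place of methyl on an aromatic carbon.

Going by the values given here, no step between measured compounds matches this change, so the expectation rests on the two values alone. The step from compound 2 to compound 3 is expected to go upward, by roughly a 3.9-fold higher number from compound 2 to compound 3 (0.59 log units; beyond the scatter), because compound 2 gives 0.517 h while compound 1 gives 7.3 h and compound 3 likewise lacks the methyl. For compound 3 the estimate is 2 h, with a range of 0.6 h to 6 h.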

Compound 3, half-life: 0.7 h
Compound 3: the middle estimate sits 2.9-fold (0.46 log units) above what was measured; the range from low to high includes it.
By their numbers in this assay, from the lowest: compounds 2 and 3 (each within the scatter of the next); then compound 1.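

Moving from methyl to (2-methoxyethyl)carbamoyl on this aromatic carbon, meta to a fused ring and para to a fused ring, gives the first one-place step in the series in this assay: a 1.4-fold higher number from compound 2 to compound 3 (0.13 log units; within the scatter). At this position, then, the much larger substituent, which brings a hydrogen-bond donor and two hydrogen-bond acceptors that methyl lacks, leaves compound 3 indistinguishable from compound 2 on half-life, and the short half-life seen with methyl is not separated from that seen with the amide side chain. Nothing at hand explains why the two compounds read alike.

Still open, from the compounds shown here alone, is whether an amine, a carboxylic acid or a longer chain on this same carbon would also stay within the scatter of compound 2, or whether some group here would shift the half-life clearly. A single step also cannot show whether the same exchange would give a similar result on the core of compound 1.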